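This account rests on a few compounds, and the source may have more. Where it says the series, first, only, none or still open, it means among the compounds named here.

Compound 1, `Oc1nc2nonc2nc1Nc1ccccc1F`, gives 12500 nM in an assay on mitochondria from L6 cells (Rattus norvegicus) for activation, with a stated time of 90 min; a lower number here means that less compound is needed, a higher number that more compound is needed for the effect.
Compound 2, `Oc1nc2nonc2nc1Nc1ccc(OC(F)(F)F)cc1Cl`, gives 1400 nM in this assay.
Compound 3, `CCCCCc1ccc(Nc2nc3nonc3nc2O)c(F)c1`, gives 1500 nM in this assay.

Among these three numbers compound 3 stands second highest: its number lies within the scatter of compound 2 and beyond the scatter from compound 1. Compound 4, `Oc1nc2nonc2nc1Nc1ccc(OC(F)(F)F)cc1F`, differs from compound 3 in one place: trifluoromethoxy in place of pentyl on an aromatic carbon. For the measured compounds named here, only one measured step touches this change: an 8.3-fold lower number from compound 1 to compound 3 (0.92 log units; beyond the scatter), a modest one. It shows that a pentyl helped, but says nothing about a trifluoromethoxy. Compound 2, which also carries a trifluoromethoxy, though with a chloro group where compound 4 has a fluoro group, gives a number within the scatter of compound 3. So for compound 4 the expected step is a 1.2-fold higher number from compound 3 to compound 4 (0.08 log units; within the scatter), nothing beyond the scatter. The estimate for compound 4 is 1800 nM, within 700 nM to 5000 nM.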

Compound 4, half-maximal effective concentration: 2300 nM
Compound 4: middle estimate off by 1.3-fold (0.11 log units), on the low side; the measured number falls inside the stated range.
By their numbers in this assay, from the lowest: compounds 2, 3 and 4 (each within the scatter of the next); then compound 1.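

In this assay, trifluoromethoxy at this position cannot be told apart from pentyl (a 1.5-fold higher number from compound 3 to compound 4 (0.19 log units; within the scatter)), although the two groups share no atoms except carbon. Trifluoromethoxy alone, with no pentyl present, also clearly lowers the number relative to hydrogen (a 5.4-fold lower number from compound 1 to compound 4 (0.74 log units; beyond the scatter)), while fluoro in place of chloro in the trifluoromethoxy pair makes no readable difference (a 1.6-fold higher number from compound 2 to compound 4 (0.22 log units; within the scatter)). No measurement at hand explains why these two different groups perform alike. Still open, on these data alone, is how an amine, a carboxylic acid or a chain longer than pentyl would fare at this position.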